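A few compounds are considered here, and "the series" means these few. Any claim that something is new, unique, unknown or untested is made for them only; others in the source may bear on it.

Measured so far:
compound 1 `Cc1cc(C)n(-c2cc(=O)cc(-c3ccccc3)[nH]2)n1`: 120000 nM
compound 2 `Cc1cc(C)n(-c2nc(C(=O)Nc3ccc(F)cc3)cc(=O)[nH]2)n1`: 200000 nM
compound 3 `Cc1cc(C2CC2)n(-c2nc(C(F)(F)F)cc(=O)[nH]2)n1`: 160000 nM

In a physicochemical assay for solubility, at pH 7.4 (a lower number here means a less soluble compound, a higher number a more soluble compound), compound 3 stands second highest of the three numbers. Its nearest neighbour is compound 2, whose number is higher, and its furthest is compound 1, whose number is lower; both gaps lie within the scatter, so the three compounds cannot be told apart on this assay.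

Compound 4 `Cc1cc(Nc2ccccn2)n(-c2nc(C(F)(F)F)cc(=O)[nH]2)n1` is not yet measured. It differs from compound 3 in one place: (pyridin-2-yl)amino in place of cyclopropyl on an aromatic carbon. Among the compounds with values here, no step between measured compounds that differ in one place is available, so the size of this step is unknown. The expectation is a small downward step, a 1.8-fold lower number from compound 3 to compound 4 (0.25 log units; within the scatter), likely within or near the scatter. Compound 4 is estimated at 90000 nM, with a range from 30000 nM to 250000 nM.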

Compound 4, solubility: 25000 nM
Beside the measured number, compound 4's estimate is 3.6-fold (0.56 log units) above it, outside the stated range (below it).
By their numbers in this assay, from the lowest: compound 4; then compounds 1, 3 and 2 (each within the scatter of the next).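

In this assay, the aromatic carbon next to the ring nitrogen proves sensitive to its substituent: (pyridin-2-yl)amino in place of cyclopropyl gives a 6.4-fold lower number from compound 3 to compound 4 (0.81 log units; beyond the scatter), a step beyond the scatter. Within the data shown here, this is the only single-place step so far, and it shows that a change at this position can move the read-out measurably. Nothing available accounts for this step.

From the compounds shown here alone, whether the step belongs to the pyridin-2-yl ring or to the amino link stays open, as one step does not separate them. Going by these compounds, how a plain amine, a phenyl ring or a morpholine at this carbon would read in this assay also stays open.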